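The compounds below may be only part of what the source reports. "The series", "measured", "known", "first", "only" and "open" are said of these compounds alone.

In an ADME assay on HuDe cells (Homo sapiens) for cytotoxicity, read by MTT assay, with a stated time of 72 h; a lower number here means a stronger inhibitor, a higher number a weaker inhibitor:
Compound 1 `NC(=O)c1cc(Cl)ccc1NC(=O)COc1ccccc1`: 808000 nM
Compound 2 `Cc1ccccc1OCC(=O)Nc1ccc(Cl)cc1C(N)=O`: 27300 nM

Of these two, compound 1 stands highest at 808000 nM. Compound 3 `Cc1ccc(NC(=O)COc2ccccc2)c(C(N)=O)c1` keeps the core of compound 1 and carries methyl in place of chloro on an aromatic carbon, para to a large group: methyl in place of chloro on an aromatic carbon. Among the measured compounds shown here, the only measured step, a 30-fold lower number from compound 1 to compound 2 (1.47 log units; beyond the scatter), was large, but it put methyl in place of hydrogen, so it bears only loosely on this change. A lower number is expected, by less than that step. The expected move is a 3.2-fold lower number from compound 1 to compound 3 (0.51 log units; beyond the scatter). For compound 3 the estimate is 250000 nM, with an expected range of 60000 nM to 900000 nM.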

Compound 3, half-maximal inhibitory concentration: 99300 nM
Beside the measured number, compound 3's estimate is 2.5-fold (0.40 log units) above it; measured number inside the range.
By their numbers in this assay, from the lowest: compound 2; then compound 3; then compound 1.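

In this assay, methyl in place of chloro para to a large group gives an 8.1-fold lower number from compound 1 to compound 3 (0.91 log units; beyond the scatter) and so moves the number. Among the compounds shown here, the earlier step put methyl in place of hydrogen at another place, so this is the only reading of the chloro position. Nothing measured here accounts for the shift.

Still open, going by these compounds, is how a methoxy group or an amine at this position would read against chloro and methyl. Also open, on these data alone, is whether this methyl and the methyl of compound 2 would add up in a single compound.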